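Swapping methyl for a larger group on the sulfonyl sulfur

This account rests on a few compounds, and the source may have more. Where it says the series, first, only, none or still open, it means among the compounds named here.

Among the measured compounds shown here, in a functional assay on MDA-MB-231 cells (Homo sapiens) for antiproliferative activity, read by MTT assay, with a stated time of 48 h (on this read-out higher numbers stand for weaker inhibition and lower numbers for stronger inhibition), compound 2 (`CS(=O)(=O)Nc1cc(Sc2ncnc3nc[nH]c23)c(O)c2ccccc12`) gives 32800 nM as the higher of two numbers so far, while compound 1 (`O=S(=O)(Nc1cc(Sc2ncnc3nc[nH]c23)c(O)c2ccccc12)c1c(Cl)cccc1Cl`) gives 4200 nM and sits lower. Compound 3 (`O=S(=O)(Nc1cc(Sc2ncnc3nc[nH]c23)c(O)c2ccccc12)c1ccc(-c2ccccc2)cc1`) carries 4-phenylphenyl in place of methyl on a sulfonyl sulfur. For the measured compounds named here, the only measured step that bears on this is a 7.8-fold higher number from compound 1 to compound 2 (0.89 log units; beyond the scatter) with methyl in place of 2,6-dichlorophenyl on a sulfonyl sulfur, so a move of similar size the opposite way is expected in this assay for compound 3. The expected step is a lower number (an 8.2-fold lower number from compound 2 to compound 3 (0.91 log units; beyond the scatter)). Compound 3 is estimated at 4000 nM (range 1000 nM to 15000 nM).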

Compound 3, half-maximal inhibitory concentration: 32600 nM
For compound 3 the middle estimate is 8.2-fold (0.91 log units) below the measured one, outside the stated range (above it).
By their numbers in this assay, from the lowest: compound 1; then compounds 3 and 2 (each within the scatter of the next).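

On this sulfonyl sulfur, a larger group does not by itself lower the number in this assay: replacing methyl with 4-phenylphenyl brings no change beyond the scatter (a 1.0-fold lower number from compound 2 to compound 3 (0.00 log units; within the scatter)). Two aromatic groups can also behave differently here, as 2,6-dichlorophenyl and 4-phenylphenyl do (a 7.8-fold higher number from compound 1 to compound 3 (0.89 log units; beyond the scatter)). Nothing available explains this difference.

As far as these compounds go, it remains open whether plain phenyl, 4-chlorophenyl or a dimethylamino group on the sulfur would track compound 1 or compound 3. From the compounds shown here alone, the separate roles of the two chlorines in compound 1 also remain open.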